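Chain length and seizure protection in a triazole series

The source may hold more compounds than are shown below. What is called first, only, known or untested is meant among the compounds shown, and "the series" means these compounds.

Of the compounds shown here, three sharing one core have been tested in a functional assay on the whole organism (strain C57B/6) with Mus musculus as the target, in the maximal electroshock model; a lower number here means that less compound is needed, a higher number that more compound is needed for the effect. Compound 1 `CCc1nncn1-c1ccc(OCc2ccc(F)cc2)cc1` gives 22.8 mg/kg. Compound 3 `CCCCCCOc1ccc(-n2cnnc2CC)cc1` gives 13.2 mg/kg, the lowest of the two numbers; the gap a 1.7-fold lower number from compound 1 to compound 3 (0.24 log units; within the scatter) lies within the scatter, so the two cannot be ranked. Compound 2 `CCCOc1ccc(-n2cnnc2CC)cc1` gives only a limit of this assay, > 100 mg/kg (the limit of > 100 mg/kg in this assay, at which 1 of the 3 values shown sits). The steps of an at least 4.3-fold higher number from compound 1 to compound 2 (0.64 log units; beyond the scatter) and an at least 7.5-fold lower number from compound 2 to compound 3 (0.87 log units; beyond the scatter) show that lengthening the chain on the oxygen from propyl to hexyl helps clearly.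

Compound 4 `CCCCCCCCCCCCOc1ccc(-n2cnnc2CC)cc1` carries the change (hexyl in place of hydrogen on a saturated chain carbon, six bonds along the chain from an oxygen on an aromatic ring), a further extension of the same chain. Only the step from compound 2 to compound 3 bears on it, and that step was large; whether a second extension repeats it, stands still, or reverses is not shown by any measured pair. The expected step of a 2.3-fold higher number from compound 3 to compound 4 (0.36 log units; beyond the scatter) is therefore a modest rise, with wide uncertainty. Compound 4 is estimated at 30 mg/kg, between 10 mg/kg and 100 mg/kg.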

Compound 4, dose for half-maximal effect: > 100 mg/kg
Compound 4 was reported as a limit (the forecaster's own chance of this, stated with the estimate: 30%); middle value at least 3.3-fold (0.52 log units) away from the limit.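

Adding hexyl at this place, six bonds along the chain from the oxygen on the aromatic ring, turns the earlier gain in this assay around: the result is an at least 7.5-fold higher number from compound 3 to compound 4 (0.87 log units; beyond the scatter). A longer chain on the oxygen is therefore not simply better, since the earlier extension gave an at least 7.5-fold lower number from compound 2 to compound 3 (0.87 log units; beyond the scatter) and this one goes the opposite way, leaving compound 3 with a lower number than both the shorter-chain compound 2 and the longer-chain compound 4. Compound 4 gives only a limit, as compound 2 does, so these two cannot be ranked against each other and the full size of the rise stays unknown: the limit of > 100 mg/kg in this assay, at which 2 of the 4 values shown sit.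

On these data alone, whether an octyl or decyl chain on the oxygen would hold the number of compound 3, improve on it or already lose it remains open. So does the effect of an amine or a carboxylic acid carried on the hexyl chain.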